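The source may report more compounds than this note shows. Statements on the series, on what has been measured and on what is new or still open speak of the compounds shown alone.

Measured compounds in the series:

- Compound 1, `Cc1ccccc1C(=O)c1ccn(-c2ccc3c(c2)B(O)OC3)c1`. In an ADME assay on L929 cells (Mus musculus) for cytotoxicity, read by resazurin assay, with a stated time of 72 h (a higher number here means a weaker inhibitor, a lower number a stronger inhibitor), compound 1 gives > 10 ug/mL, which is a limit of the assay rather than a number.
- Compound 2, `O=C(c1ccc(O)cc1)c1ccn(-c2ccc3c(c2)B(O)OC3)c1`. In this assay compound 2 gives > 10 ug/mL, again a limit of the assay and not a number.

Compound 2 therefore stands nowhere definite on the scale: its value is a limit only, and the further value shown for the series is a limit as well. Among the measured compounds shown here, the one step between measured compounds, a step that the two limits leave unreadable from compound 1 to compound 2, cannot be read because both ends are limits; the limit of > 10 ug/mL in this assay, at which 2 of the 2 values shown sit, is all the evidence there is, and it fixes no size for any change.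

Compound 3, `O=C(c1ccn(-c2ccc3c(c2)B(O)OC3)c1)C1CCCCC1`, is not yet measured. It differs from compound 2 in one place: cyclohexyl in place of 4-hydroxyphenyl on a carbonyl carbon. For the measured compounds named here, no measured step bears on this change in a readable way, so no direction and no size can be drawn from the series; a step within the scatter, or none at all, is as plausible as any other.

Compound 3 is expected to give 15 ug/mL in this assay, within 4 ug/mL to 60 ug/mL, an estimate that corresponds to a step that the limit leaves unreadable from compound 2 to compound 3 and that most likely comes back as a limit once more.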

Compound 3, half-maximal inhibitory concentration: > 10 ug/mL
Compound 3: no number, only a limit (the forecaster's own chance of this, stated with the estimate: 70%); the middle value does not contradict the limit.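

In this assay compound 3 gives > 10 ug/mL, a limit of the assay and not a number. No new step can be read between compound 3 and either compound 1 or compound 2, so the series rests on one limit: the limit of > 10 ug/mL in this assay, at which 3 of the 3 values shown sit. The compounds shown leave open the actual half-maximal inhibitory concentration of each compound, and whether exchanging the group on the carbonyl carbon changes it at all.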